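The compounds below may be only part of what the source reports. "The series", "measured", "known", "first", "only" and "open" are said of these compounds alone.

In a functional assay on RAW264.7 cells (Mus musculus) for inhibition, read by ELISA, with a stated time of 24 h (a lower number here means that less compound is needed, a higher number that more compound is needed for the effect), compound 1 `CC/C=C\C[C@H]1C(=O)C=C[C@H]1CC(=O)OCCCC` gives 23000 nM and compound 2 `CC/C=C\C[C@H]1C(=O)C=C[C@H]1CC(=O)OCCOCCO` gives 36000 nM, two values within the usual scatter of each other. Compound 3 `CC/C=C\C[C@H]1C(=O)C=C[C@H]1CC(=O)OCCOCCOCCOC` differs from compound 2 by 2-methoxyethyl in place of hydrogen on an oxygen on a saturated carbon, with 2-methoxyethyl in place of hydrogen on an oxygen on a saturated carbon. Among the measured compounds shown here, only one measured step bears on this change: a 1.6-fold higher number from compound 1 to compound 2 (0.19 log units; within the scatter), where 2-hydroxyethoxy replaces ethyl. A single small step is thin evidence, so no shift beyond the scatter is expected in this assay. For compound 3 the estimated value is 40000 nM, with an expected range of 15000 nM to 100000 nM. The expected change is a 1.1-fold higher number from compound 2 to compound 3 (0.05 log units; within the scatter).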

Compound 3, half-maximal effective concentration: 35000 nM
Compound 3: the middle estimate sits 1.1-fold (0.06 log units) above what was measured; the measured number falls inside the stated range.
By their numbers in this assay, from the lowest: compounds 1, 3 and 2 (each within the scatter of the next).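

In this assay, 2-methoxyethyl on the end oxygen of the chain gives a 1.0-fold lower number from compound 2 to compound 3 (0.01 log units; within the scatter), so removing the free hydroxy hydrogen produces no readable shift. Against the plain butyl chain of compound 1, the full 2-(2-methoxyethoxy)ethoxy replacement gives a 1.5-fold higher number from compound 1 to compound 3 (0.18 log units; within the scatter), so this longer ether chain also stays within the scatter. No available measurement explains this result. The compounds shown leave open whether an amine or a carboxylic acid at the chain end would move the number beyond the scatter. Going by these compounds, a much longer chain remains equally open.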